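The source may report more compounds than this note shows. Statements on the series, on what has been measured and on what is new or still open speak of the compounds shown alone.

Three compounds have been measured so far in an ADME assay on MRC5 cells (Homo sapiens) for cytotoxicity, read by fluorescence and resazurin assay, with a stated time of 3 days; a higher number here means that more compound is needed for the effect, a lower number that less compound is needed:

- Compound 1 `O=C1C=CC(O)(c2nc3ccccc3s2)C(Cl)=C1` gives 55 nM
- Compound 2 `O=C1C=CC(O)(c2cc3cnccc3n2S(=O)(=O)c2ccccc2)C=C1` gives 41 nM
- Compound 3 `CCOC(=O)Nc1ccc(S(=O)(=O)n2c(C3(O)C=CC(=O)C=C3)cc3ccccc32)cc1` gives 86 nM

In this assay compound 3 at 86 nM lies within the scatter of compound 1 at 55 nM and is not separated from it. The gap to compound 2 at 41 nM lies just beyond the scatter, and compound 2 has the lower number.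

The next compound is compound 4 `O=C1C=CC(O)(c2cc3ccccc3n2S(=O)(=O)c2ccc(CCC(=O)N3CCOCC3)cc2)C=C1`, which has not yet been measured. Compared with compound 3, it carries 2-((morpholin-4-yl)carbonyl)ethyl in place of (ethoxycarbonyl)amino on an aromatic carbon, para to a large group, and the count of that change reads 2-((morpholin-4-yl)carbonyl)ethyl in place of (ethoxycarbonyl)amino on an aromatic carbon in full.

Going by the values given here, no measured pair here differs in one place only, so the data offer no direct precedent for this change. The expectation rests only on how closely the values sit, even though the structures of compound 2 at 41 nM and compound 3 at 86 nM differ in more than one place. The expected size is a 1.1-fold lower number from compound 3 to compound 4 (0.03 log units; within the scatter) in this assay, which is estimated to stay within the scatter and to favour no clear direction. For compound 4 the estimate is 80 nM with an expected range from 35 nM to 190 nM in this measurement.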

Compound 4, half-maximal effective concentration: 67 nM
Estimate against measurement, compound 4: 1.2-fold (0.08 log units) above; the measured number falls inside the stated range.
By their numbers in this assay, from the lowest: compounds 2, 1, 4 and 3 (each within the scatter of the next, the first and the last beyond it).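

Going by these compounds alone, the step gives the first direct reading at this place, on an aromatic carbon of a six-membered aromatic ring of carbon only, para to a large group: in this assay, putting 2-((morpholin-4-yl)carbonyl)ethyl in place of (ethoxycarbonyl)amino gives a 1.3-fold lower number from compound 3 to compound 4 (0.11 log units; within the scatter) and does not separate the two compounds. The entering group has 10 heavy atoms against 6 for the group that leaves, adds a six-membered non-aromatic ring and has no hydrogen-bond donor, yet this whole exchange leaves the number within the scatter. No supporting measurement accompanies this result, so the data offer no account of why the number holds.

As far as these compounds go, this is a single step at a single place, so it remains open whether an amine, a carboxylic acid or a longer chain there would move the number in this assay beyond the scatter. From the compounds shown here alone, it also remains open whether the same exchange would hold on the core of compound 2, which has the lowest number so far.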